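This account rests on a few compounds, and the source may have more. Where it says the series, first, only, none or still open, it means among the compounds named here.

Working notes on the series, all read in a functional assay on MCF7 cells (Homo sapiens) for cytotoxicity, with a stated time of 72 h; a lower number here means a stronger inhibitor, a higher number a weaker inhibitor. Compound 1 (`CC1c2c(-c3ccncc3)c(-c3ccccc3C#N)nn2CC1(C)C`) gives > 100000 nM, which is a limit and not a number. Compound 2 (`Cc1cc(-c2c(-c3cccc(C)n3)nn3c2C(C)C(C)(C)C3)ccn1`) gives > 100000 nM, again a limit. Compound 3 (`Cc1cccc(-c2nn3c(c2-c2ccncc2)CC(C)(C)C3)n1`) gives > 100000 nM, also a limit. The overall picture so far is the limit of > 100000 nM in this assay, at which 3 of the 3 values shown sit. For the measured compounds named here, compound 3 therefore offers no numerical starting point, and no step between measured compounds is available for sizing a change.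

The next compound is compound 4 (`Cc1cccc(-c2nn3c(c2-c2ccncc2)C(C)C(C)(C)C3)n1`), which differs from compound 3 as follows: methyl in place of hydrogen on a saturated ring carbon. In short, this is methyl in place of hydrogen on a saturated ring carbon, and the rest of the structure is unchanged.

Going by the values given here, with no measured step to draw on, the expectation is for no change beyond the usual scatter, in either direction, and for compound 4 most likely to be reported as a limit again. This expectation rests on compound 3, whose reading of > 100000 nM is a limit. The expected change is a number no higher from compound 3 to compound 4 (the limit leaves the size open). For compound 4 the estimated value is 100000 nM, with an expected range of 60000 nM to 200000 nM.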

Compound 4, half-maximal inhibitory concentration: > 100000 nM
Compound 4: a limit, no number (the forecaster's own chance of this, stated with the estimate: 85%); the middle value sits exactly at the limit.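

No step can be read from compound 1, compound 2 or compound 3 to compound 4, as each pair joins two limits and not numbers. The compounds shown leave open the size of these changes, and whether any change on the shared core gives a measurable value in this assay: the limit of > 100000 nM in this assay, at which 4 of the 4 values shown sit.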